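Hydroxy to trifluoromethyl: compound 3 to compound 4

The source may hold more compounds than are shown below. What is called first, only, known or untested is meant among the compounds shown, and "the series" means these compounds.

In a functional assay on L1210 cells (Mus musculus) for inhibition, read by MTT assay, with a stated time of 72 h (a higher number here means a weaker inhibitor, a lower number a stronger inhibitor), compound 1 (`COc1cc(NC(C)CCCNC(=O)Nc2cccc(Cl)c2)c2ncccc2c1`) gives 17000 nM, compound 2 (`COc1cc(NC(C)CCCNC(=O)Nc2ccc(F)cc2)c2ncccc2c1`) gives 18000 nM and compound 3 (`COc1cc(NC(C)CCCNC(=O)Nc2cccc(O)c2)c2ncccc2c1`) gives 25000 nM. Compound 3 therefore stands within the scatter of both others. Compound 4 (`COc1cc(NC(C)CCCNC(=O)Nc2cccc(C(F)(F)F)c2)c2ncccc2c1`) carries trifluoromethyl in place of hydroxy on an aromatic carbon, meta to a large group: trifluoromethyl in place of hydroxy on an aromatic carbon. The measured steps that bear on this change are a 1.5-fold higher number from compound 1 to compound 3 (0.17 log units; within the scatter), a 1.4-fold higher number from compound 2 to compound 3 (0.14 log units; within the scatter) and a 1.1-fold higher number from compound 1 to compound 2 (0.02 log units; within the scatter), and all three stay within the scatter. No change beyond the scatter is therefore expected in this assay. The expected step is a 1.4-fold lower number from compound 3 to compound 4 (0.14 log units; within the scatter), which also lies within the scatter. For compound 4 the estimated value is 18000 nM, with an expected range of 10000 nM to 32000 nM.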

Compound 4, half-maximal inhibitory concentration: 9200 nM
Compound 4: the middle estimate sits 2.0-fold (0.29 log units) above what was measured, outside the stated range (below it).
By their numbers in this assay, from the lowest: compounds 4, 1, 2 and 3 (each within the scatter of the next, the first and the last beyond it).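

In this assay, among these compounds, the change at this aromatic carbon gives the first step beyond the scatter: a 2.7-fold lower number from compound 3 to compound 4 (0.43 log units; beyond the scatter), a modest step on going from hydroxy to trifluoromethyl. The other new steps, a 2.0-fold lower number from compound 2 to compound 4 (0.29 log units; within the scatter) and a 1.8-fold lower number from compound 1 to compound 4 (0.27 log units; within the scatter), stay within the scatter, so compound 4 separates only from compound 3, and trifluoromethyl and chloro at this carbon are not told apart. No data at hand account for the step.

On these data alone, whether the step comes from losing hydroxy or from gaining trifluoromethyl remains open. Also open, as far as these compounds go, is how an amine or a carboxylic acid at this carbon would read.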